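From thiophen-2-yl to piperidin-1-yl on a carbonyl carbon

The source may report more compounds than this note shows. Statements on the series, on what has been measured and on what is new or still open speak of the compounds shown alone.

Of the compounds shown here, three have been measured so far. In an ADME assay on HepG2 cells (Homo sapiens) for inhibition, read by resazurin assay, with a stated time of 48 h (on this read-out lower numbers stand for an effect already at smaller amounts and higher numbers for an effect only at larger amounts of compound), compound 1 (`O=C(Nc1ccc2sc(-c3cccc(F)c3)nc2c1)N1CCCCC1`) gives > 50000 nM as a limit of the assay, not a number. Compound 3 (`O=C(Nc1ccc2sc(-c3ccccc3F)nc2c1)N1CCCC1`) gives > 50000 nM as a limit of the assay as well. Compound 2 (`O=C(Nc1ccc2sc(-c3ccccc3)nc2c1)c1cccs1`) gives > 50000 nM as a limit too, so it has no numerical position in the series. The whole set stands at the limit of > 50000 nM in this assay, at which 3 of the 3 values shown sit, with no number to rank.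

Compound 4 (`O=C(Nc1ccc2sc(-c3ccccc3)nc2c1)N1CCCCC1`) has piperidin-1-yl in place of thiophen-2-yl on a carbonyl carbon of compound 2 piperidin-1-yl in place of thiophen-2-yl on a carbonyl carbon and is otherwise unchanged. Going by the values given here, no measured pair differs in one place only. The expectation leans on compound 1, which carries piperidin-1-yl on a carbonyl carbon and gives > 50000 nM as a limit. The expected step of a number no higher from compound 2 to compound 4 (the limit leaves the size open) is none beyond the usual scatter, with no direction foreseen. The estimate for compound 4 is 50000 nM with an expected range of 25000 nM to 100000 nM and most likely another report as a limit.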

Compound 4, half-maximal effective concentration: > 50000 nM
Compound 4: a limit, no number; the forecaster's own chance of this, stated with the estimate: 85%; the middle value sits exactly at the limit.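

Compound 4 gives > 50000 nM, a limit of the assay and not a number, so its steps from compound 1 and compound 2 cannot be read. The compounds shown leave open whether any group on the carbonyl carbon gives a readable value in this assay: the limit of > 50000 nM in this assay, at which 4 of the 4 values shown sit.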